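Chloro in place of methyl on the sulfonyl chain

This account rests on a few compounds, and the source may have more. Where it says the series, first, only, none or still open, it means among the compounds named here.

In a functional assay on Huh-7 cells (Homo sapiens) for cytotoxicity, read by MTT assay, with a stated time of 72 h (a higher number here means that more compound is tolerated, a lower number that less compound is tolerated), compound 1 (`CCS(=O)(=O)N1CCC2(CC1)OOC1(CCCCCC1)OO2`) gives > 100 ug/mL as a limit of the assay. Compound 2 (`CCCS(=O)(=O)N1CCC2(CC1)OOC1(CCCCCC1)OO2`) gives > 100 ug/mL as a limit too. Compound 3 (`CCCCS(=O)(=O)N1CCC2(CC1)OOC1(CCCCCC1)OO2`) stands at > 100 ug/mL and this is again a limit. Among the measured compounds shown here, the series so far sits at the limit of > 100 ug/mL in this assay, at which 3 of the 3 values shown sit, and offers no number. Compound 4 (`O=S(=O)(CCCCl)N1CCC2(CC1)OOC1(CCCCCC1)OO2`) has chloro in place of methyl on a saturated chain carbon, three bonds along the chain from a sulfonyl sulfur, butyl to 3-chloropropyl (chloro in place of methyl on a saturated chain carbon, three bonds along the chain from a sulfonyl sulfur). The steps a step that the two limits leave unreadable from compound 1 to compound 2 and a step that the two limits leave unreadable from compound 1 to compound 3 and a step that the two limits leave unreadable from compound 2 to compound 3 bear on it, none has a readable size and none brings in chloro, so no shift beyond the scatter is expected in this assay for this change. The estimated step (a step that the limit leaves unreadable from compound 3 to compound 4) is only an expectation. For compound 4 the estimated value is 120 ug/mL with an expected range from 60 ug/mL to 240 ug/mL in this series.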

Compound 4, half-maximal cytotoxic concentration: > 100 ug/mL
Compound 4 gave a limit, no number (the forecaster's own chance of this, stated with the estimate: 80%); the middle value does not contradict the limit.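

Among the compounds shown here, no step among compound 1, compound 2, compound 3 and compound 4 can be read in this assay as all remain limits: the limit of > 100 ug/mL in this assay, at which 4 of the 4 values shown sit. On these data alone, whether the sulfonyl chains differ at all in this assay stays open, as does the size of any such difference.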